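Third methoxy group on the diaryl-propane series

The compounds below may be only part of what the source reports. "The series", "measured", "known", "first", "only" and "open" are said of these compounds alone.

Compound 2 `COc1ccc(CCCc2ccc(OC)cc2OC)c(O)c1` gives 91.5% in an ADME assay on RAW264.7 cells (Mus musculus) for cytotoxicity, read by MTT assay, with a stated time of 24 h, tested at 5 ug/mL; on this read-out lower numbers stand for a stronger effect and higher numbers for a weaker effect at the one concentration tested. Compound 1 `COc1ccc(CCCc2ccc(OC)c(OC)c2)c(O)c1` gives 88.9%, and compound 3 `COc1ccc(CCCc2ccc(OC)cc2O)cc1` gives 94.6%; compound 2 lies within the scatter of both, so the three measured values are indistinguishable on this read-out. Compound 4 `COc1ccc(CCCc2ccc(OC)c(OC)c2OC)c(O)c1` differs from compound 2 by methoxy in place of hydrogen on an aromatic carbon. Among the measured compounds shown here, the only measured steps that touch this change run the other way, removing a methoxy: a number 5.7 percentage points higher from compound 1 to compound 3 (within the scatter) and a number 3.1 percentage points higher from compound 2 to compound 3 (within the scatter), neither beyond the scatter. Both steps involve a methoxy on an aromatic carbon, and neither moved the number. For the measured compounds named here, the two measured steps give no sign that adding or removing a methoxy shifts the read-out, though no measured step adds a methoxy where the change to compound 4 does. On that basis compound 4 is expected to give 90%, in the range 81% to 98%; the estimated step of a number 1.5 percentage points lower from compound 2 to compound 4 (within the scatter) is expected to stay within the scatter, with no direction beyond it.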

Compound 4, a percentage reported as activity, at one concentration (the size of the read-out at that concentration, not a potency): 84.5%
The estimate for compound 4 lay 5.5 percentage points above the measured number; low and high end bracket the measured number.
By their numbers in this assay, from the lowest: compounds 4, 1, 2 and 3 (each within the scatter of the next, the first and the last beyond it).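

In this assay, methoxy in place of hydrogen on an aromatic carbon, ortho to two methoxy groups in the step from compound 2, now reads in the adding direction, and neither step leaves the scatter: a number 7 percentage points lower from compound 2 to compound 4 (within the scatter), and a number 4.4 percentage points lower from compound 1 to compound 4 (within the scatter). Removing a methoxy reads alike on the two cores of compound 1 and compound 4: the same change on two cores in this assay, a number 5.7 percentage points higher (within the scatter) from compound 1 to compound 3 and a number 7 percentage points higher (within the scatter) from compound 4 to compound 2, 1.3 percentage points apart, within the scatter of two such steps Removing a methoxy also reads alike on the two cores of compound 2 and compound 4: the same change on two cores in this assay, a number 3.1 percentage points higher (within the scatter) from compound 2 to compound 3 and a number 4.4 percentage points higher (within the scatter) from compound 4 to compound 1, 1.3 percentage points apart, within the scatter of two such steps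

On these data alone, whether an amine, a carboxylic acid or a longer chain such as ethoxy at this place would move the number beyond the scatter stays open. As far as these compounds go, all the numbers come from one concentration, so the shape of any concentration response in this assay also stays open.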